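The source may report more compounds than this note shows. Statements on the series, on what has been measured and on what is new or still open speak of the compounds shown alone.

In a functional assay, read by spectrophotometry, with a stated time of 6 min (on this read-out higher numbers stand for weaker inhibition and lower numbers for stronger inhibition), compound 3 (`CCCCCCCCOc1cc(OC)ccc1C(C)=O`) gives 38300000 nM and compound 2 (`CCCCCCOc1cc(OC)ccc1C(C)=O`) gives 42100000 nM while compound 1 (`CCCCCCCCCCOc1cc(OC)c(Br)cc1C(C)=O`) gives 34700000 nM and these three numbers all lie within the usual scatter of one another, which leaves compound 3 among them with no real separation. For the measured compounds named here, the single change to compound 4 (`CCCCCCCCCCOc1cc(OC)ccc1C(C)=O`) is ethyl in place of hydrogen on a saturated chain carbon, eight bonds along the chain from an oxygen on an aromatic ring and it lengthens the chain of compound 3 further. The same kind of change made six bonds along the chain gave a 1.1-fold lower number from compound 2 to compound 3 (0.04 log units; within the scatter) and so moved the number by no more than the scatter. The chain of compound 4 also occurs in compound 1, which carries a bromine as well and gives 34700000 nM within the scatter of the other two. No step beyond the scatter is therefore expected in this assay in either direction, and the estimated step is a 1.1-fold lower number from compound 3 to compound 4 (0.03 log units; within the scatter) on this evidence. For compound 4 the estimated value is 36000000 nM with an expected range from 20000000 nM to 65000000 nM as the likely span.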

Compound 4, half-maximal inhibitory concentration: 41700000 nM
Estimate against measurement, compound 4: 1.2-fold (0.06 log units) below; the range from low to high includes it.
By their numbers in this assay, from the lowest: compounds 1, 3, 4 and 2 (each within the scatter of the next).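

In this assay, adding ethyl eight bonds along the chain gives a 1.1-fold higher number from compound 3 to compound 4 (0.04 log units; within the scatter) and so, like the same change made six bonds along, it stays within the scatter. Taking both extensions together, butyl in place of hydrogen six bonds along the chain gives a 1.0-fold lower number from compound 2 to compound 4 (0.00 log units; within the scatter) and shows that the two small steps do not build into a larger one across these three chain lengths. Compound 1 and compound 4 also now form a pair differing in one place: hydrogen in place of bromo on an aromatic carbon gives a 1.2-fold higher number from compound 1 to compound 4 (0.08 log units; within the scatter) and this too lies within the scatter.

No evidence is available to explain why the numbers stay so close. On these data alone, whether a longer chain, an amine or a carboxylic acid would move the number beyond the scatter remains open.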